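Phenyl for Allyl on an Aromatic Nitrogen

The source may report more compounds than this note shows. Statements on the series, on what has been measured and on what is new or still open speak of the compounds shown alone.

Of the compounds shown here, three have been tested in a functional assay on the whole organism (strain albino) for inhibition, with Rattus norvegicus as the target, read by paw edema, with stated times of 30 min and 1 h, at a dose of 0.28 mmol/kg by the oral route; a lower number here means less inhibition, a higher number more inhibition at the dose given (going by the name of the read-out). Compound 1, `COc1ccc(-c2nnc(SCC(=O)Nc3ccc(/C(C)=N/O)cc3)n2-c2ccccc2)cc1OC`, gives 57%. Compound 2, `C=CCn1c(SCC(=O)Nc2ccc(/C(C)=N/O)cc2)nnc1-c1ccc(OC)c(OC)c1`, gives 53%, and compound 3, `C=CCn1c(SCC(=O)Nc2ccc(C(C)=O)cc2)nnc1-c1ccc(OC)cc1`, gives 50%. Compounds 2 and 1 differ in one place: phenyl in place of allyl on an aromatic nitrogen. That change gave a number 4 percentage points higher from compound 2 to compound 1 (within the scatter). The difference between the cores of compound 3 and compound 2 is not broken down here. Compound 4, `COc1ccc(-c2nnc(SCC(=O)Nc3ccc(C(C)=O)cc3)n2-c2ccccc2)cc1`, differs from compound 3 by the same kind of change: phenyl in place of allyl on an aromatic nitrogen. The surroundings are not identical: in compound 2 the ring atom next to the changed nitrogen bears a 3,4-dimethoxyphenyl group, in compound 3 a 4-methoxyphenyl group. A step of similar size is expected here, a number 4 percentage points higher from compound 3 to compound 4 (within the scatter), because the earlier one was a number 4 percentage points higher from compound 2 to compound 1 (within the scatter). Compound 4 is thus estimated at 54%, with a likely range from 44% to 64%.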

Compound 4, a percentage reported as inhibition, in the whole organism at one dose (the size of the read-out at that dose, not a potency): 29%
Beside the measured number, compound 4's estimate is 25 percentage points above it, and the stated range ends above it.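

On the second core, phenyl in place of allyl on the aromatic nitrogen gave, in this assay, a number 21 percentage points lower from compound 3 to compound 4 (beyond the scatter). The change therefore did not carry over from one core to the other with the same size or direction: the same change on two cores in this assay, a number 4 percentage points higher (within the scatter) from compound 2 to compound 1 and a number 21 percentage points lower (beyond the scatter) from compound 3 to compound 4, 25 percentage points apart, beyond the scatter of two such steps. This shows that a step seen on one core cannot simply be assumed on another in this series, but it does not show which difference between the cores is responsible, and the 3,4-dimethoxyphenyl and 4-methoxyphenyl groups are only one of the differences.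

The compounds shown carry only allyl or phenyl on this nitrogen. As far as these compounds go, how a longer alkyl chain or a chain ending in an amine would read there on either core remains open.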